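Trimming the Amide Side Chain on a Chemokine Receptor Antagonist

A few compounds are considered here, and "the series" means these few. Any claim that something is new, unique, unknown or untested is made for them only; others in the source may bear on it.

Of the compounds shown here, two sharing one core have been measured in a functional assay on U2OS cells for antagonist activity at C-X-C chemokine receptor type 3 (Homo sapiens), read by beta-arrestin recruitment; a lower number here means a stronger inhibitor, a higher number a weaker inhibitor. Compound 1 `C[C@@H]1CN(c2sc(C(F)(F)F)nc2-c2nc3ccccc3[nH]2)CCN1C(=O)Cn1cnc2cccnc21` gives 31 nM. Compound 2 `CCOc1ncc(-c2nc(C(F)(F)F)sc2N2CCN(C(=O)Cn3ccc4cccnc43)[C@H](C)C2)cn1` gives 47 nM, the higher of the two numbers, though its gap to compound 1 lies within the scatter. Compound 3 `CCOc1ncc(-c2nc(C(F)(F)F)sc2N2CCN(C(=O)Cn3nccc3C)[C@H](C)C2)cn1` differs from compound 2 by a single change: a group of 6 heavy atoms (4 carbon, 2 nitrogen; one five-membered aromatic ring with 2 hetero atoms) in place of a group of 9 heavy atoms (7 carbon, 2 nitrogen; one five-membered aromatic ring with 1 hetero atom, one six-membered aromatic ring with 1 hetero atom), on a saturated chain carbon bound to a carbonyl carbon. Among the compounds with values here, no measured pair covers this change, so its size can only be guessed. The step of a 2.1-fold higher number from compound 2 to compound 3 (0.33 log units; beyond the scatter) is expected to be modest, toward a weaker inhibitor, and may not exceed the scatter. Compound 3 is therefore expected at 100 nM, within a range of 30 nM to 400 nM.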

Compound 3, half-maximal inhibitory concentration: 162 nM
For compound 3 the middle estimate is 1.6-fold (0.21 log units) below the measured one; measured number inside the range.
By their numbers in this assay, from the lowest: compounds 1 and 2 (each within the scatter of the next); then compound 3.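

Replacing the two-ring group on the saturated chain carbon bound to a carbonyl carbon with 5-methyl-1H-pyrazol-1-yl gives a 3.4-fold higher number from compound 2 to compound 3 (0.54 log units; beyond the scatter) in this assay. This shows that the group at this position affects the result, and that the two-ring group of compound 2 gives the lower number of this pair. Even so, the single-ring compound 3 still inhibits, at 162 nM. Nothing available explains the size of this step. Going by these compounds, whether a phenyl ring, or a pyrazole without its methyl, would give a lower number at this position remains open.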